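The source may hold more compounds than are shown below. What is called first, only, known or untested is meant among the compounds shown, and "the series" means these compounds.

Measured compounds in an ADME assay on MT2 cells (Homo sapiens) for cytotoxicity, read by XTT assay, with a stated time of 4 days; a lower number here means that less compound is tolerated, a higher number that more compound is tolerated:
compound 1 `Cc1cc(/C=C2\SC(=S)N(Cc3ccccc3)C2=O)c(C)n1-c1ccc(O)c(C(=O)O)c1` gives 159000 nM
compound 2 `Cc1cc(/C=C2\SC(=S)N(Cc3ccc(C(C)(C)C)cc3)C2=O)c(C)n1-c1ccc(O)c(C(=O)O)c1` gives 55200 nM
compound 3 `Cc1cc(/C=C2\SC(=S)N(Cc3ccccc3C(F)(F)F)C2=O)c(C)n1-c1ccc(O)c(C(=O)O)c1` gives 28800 nM

Compound 1 stands highest of the three: a 2.9-fold lower number from compound 1 to compound 2 (0.46 log units; beyond the scatter) and a 5.5-fold lower number from compound 1 to compound 3 (0.74 log units; beyond the scatter), while a 1.9-fold lower number from compound 2 to compound 3 (0.28 log units; within the scatter).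

Compound 4 `Cc1cc(/C=C2\SC(=S)N(Cc3ccccc3)C2=O)c(C)n1-c1cccc(C(=O)O)c1` differs from compound 1 in one place: hydrogen in place of hydroxy on an aromatic carbon. The hydroxy sits on the aromatic ring that carries the carboxy group, far from where the measured compounds differ.

The measured steps all concern substituents on the benzyl ring and say nothing about the ring bearing the carboxy group. Among the measured compounds shown here, no measured step bears on this change, so no step beyond the scatter is expected in this assay. For compound 4 the expected value in this assay is 140000 nM, in the range 50000 nM to 400000 nM, which means an expected step of a 1.1-fold lower number from compound 1 to compound 4 (0.06 log units; within the scatter).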

Compound 4, half-maximal cytotoxic concentration: 83400 nM
Compound 4: middle estimate off by 1.7-fold (0.22 log units), on the high side; measured number inside the range.
By their numbers in this assay, from the lowest: compounds 3, 2, 4 and 1 (each within the scatter of the next, the first and the last beyond it).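

Hydrogen in place of hydroxy on the 3-carboxy-4-hydroxyphenyl ring, the only change shown away from the benzyl ring, gives in this assay a 1.9-fold lower number from compound 1 to compound 4 (0.28 log units; within the scatter) and so stays within the scatter. At this position, ortho to a carboxy group, the hydroxy can therefore go without a readable difference in this assay. Nothing shown here explains this result.

Still open, as far as these compounds go, is whether a methoxy group or an amine at this position would also leave the number within the scatter. Also open, from the compounds shown here alone, is whether losing the hydroxy gives a similar step when the benzyl ring carries tert-butyl or trifluoromethyl.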